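This account rests on a few compounds, and the source may have more. Where it says the series, first, only, none or still open, it means among the compounds named here.

Working notes on the series. For the measured compounds named here, compound 2 `Cc1ccccc1Cc1ccc(N2CCC[C@H]2CC(=O)O)cc1` in a functional assay on cells for agonist activity at Free fatty acid receptor 1 (Mus musculus), read by FLIPR and calcium flux, with a stated time of 100 s (a lower number here means that less compound is needed, a higher number that more compound is needed for the effect), gives only a limit, > 33000 nM; it is the one value of the three that sits at the limit of > 33000 nM in this assay, at which 1 of the 3 values shown sits, so compound 2 stands without a number of its own and is placed only by what that limit allows. Compound 3 `Cc1ccccc1Cc1ccc(N2CC[C@H](C)[C@H]2CC(=O)O)cc1` carries a methyl on a saturated ring carbon and in this assay gives 1900 nM. Going by the values given here, the step of an at least 17-fold lower number from compound 2 to compound 3 (1.23 log units; beyond the scatter) is the single measured step that bears on the present change, a substitution at the same place of the ring. Compound 1 `Cc1ccccc1Oc1ccc(N2C[C@@H](C(F)(F)F)C[C@H]2CC(=O)O)cc1` in this assay gives 330 nM; it carries the trifluoromethyl group but is joined through an ether rather than a methylene link, so it differs from compound 2 in two places and offers a value only, not a step. Compound 4 `Cc1ccccc1Cc1ccc(N2C[C@@H](C(F)(F)F)C[C@H]2CC(=O)O)cc1` is not yet measured. It differs from compound 2 by trifluoromethyl in place of hydrogen on a saturated ring carbon. Given that a methyl at this place produced the large step from compound 2 to compound 3, a step of comparable or greater size in the same direction is expected here, while the ether-to-methylene difference between compound 1 and compound 4 leaves the exact size open. Compound 4 is therefore estimated at 1000 nM in this assay, within 250 nM to 4000 nM. The expected step is an at least 33-fold lower number from compound 2 to compound 4 (1.51 log units; beyond the scatter).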

Compound 4, half-maximal effective concentration: 710 nM
Estimate against measurement, compound 4: 1.4-fold (0.15 log units) above; low and high end bracket the measured number.
By their numbers in this assay, from the lowest: compound 1; then compound 4; then compound 3. At a limit, above all of these: compound 2.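

In this assay, trifluoromethyl on a saturated ring carbon, two ring bonds from the ring nitrogen, gives a measured number on the 2-methylbenzyl core, with an at least 46-fold lower number from compound 2 to compound 4 (1.66 log units; beyond the scatter), so this position accepts a group of 4 heavy atoms as well as a hydrogen. On these data alone, compound 2 is held only by a limit, so the true size of that step stays unknown: the limit of > 33000 nM in this assay, at which 1 of the 4 values shown sits. With trifluoromethyl present, the exchange of 2-methylphenoxy for 2-methylbenzyl is a modest change, with a 2.2-fold higher number from compound 1 to compound 4 (0.33 log units; beyond the scatter), so a measured number in this pair does not depend on the ether link alone.

The compounds shown leave open whether a hydroxyl group, an amine or an ethyl chain at this ring carbon would give a step of similar size, and how the opposite configuration at this carbon would read. They also leave open whether the exchange of 2-methylphenoxy for 2-methylbenzyl would stay modest on a core that carries hydrogen at this place.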